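The source may hold more compounds than are shown below. What is called first, only, known or untested is meant among the compounds shown, and "the series" means these compounds.

The study follows antiproliferative potency in a functional assay on HCT-116 cells (Homo sapiens) for antiproliferative activity, read by MTT assay, with a stated time of 48 h; a lower number here means a stronger inhibitor, a higher number a weaker inhibitor. Compound 1 `N#CC1=C(N)Oc2c(c3nc4ccccc4nc3c3ccccc23)C12C(=O)N(Cc1cnnn1-c1cccc(S(N)(=O)=O)c1)c1ccccc12` gives 11300 nM in this assay. Compound 2 `Cc1cccc(-n2nncc2CN2C(=O)C3(C(C#N)=C(N)Oc4c(N)cc5nc6ccccc6nc5c43)c3ccccc32)c1` yields only a limit in this assay, > 50000 nM, so no number is known for it. Of the two values shown, one sits at the limit of > 50000 nM in this assay, at which 1 of the 2 values shown sits, and compound 2 is that one; it therefore stands as the weaker of the two compounds measured. Compound 3 `Cc1ccc(-n2nncc2CN2C(=O)C3(C(C#N)=C(N)Oc4c(N)cc5nc6ccccc6nc5c43)c3ccccc32)cc1Cl` differs from compound 2 by 3-chloro-4-methylphenyl in place of 3-methylphenyl on an aromatic nitrogen. Among the compounds with values here, no measured step between compounds that differ in a single place is available, so the size of this change cannot be read from a neighbouring pair. The expected step in this assay is an at least 1.1-fold lower number from compound 2 to compound 3 (0.04 log units; that floor lies within the scatter), a change not beyond the usual scatter. For compound 3 the estimate in this assay is 45000 nM, within a range from 12000 nM to 100000 nM, and a limit rather than a number is quite possible.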

Compound 3, half-maximal inhibitory concentration: > 50000 nM
Compound 3: a limit, no number (the forecaster's own chance of this, stated with the estimate: 60%); at least 1.1-fold (0.04 log units) between middle value and limit.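

Compound 2 and compound 3 both stand only as limits, so no step between them can be read: the limit of > 50000 nM in this assay, at which 2 of the 3 values shown sit.

The compounds shown leave open whether 3-chloro-4-methylphenyl in place of 3-methylphenyl on an aromatic nitrogen changes the result in this assay at all, and by how much.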